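A few compounds are considered here, and "the series" means these few. Any claim that something is new, unique, unknown or untested is made for them only; others in the source may bear on it.

Among the compounds with values here, compound 2 `COc1cc(-c2nn(-c3cccc(NC(=O)Nc4ccc(Cl)c(Cl)c4)c3)cc2-c2ccncc2)ccc1Cl` is one of three compounds measured in a functional assay on NCI-H226 cells (Homo sapiens) for inhibition, read by sulforhodamine B assay, with a stated time of 48 h; on this read-out lower numbers stand for higher toxicity in this test and higher numbers for lower toxicity in this test. In this assay compound 2 reaches only a limit, > 50000 nM. Compound 1 `COc1cc(-c2nn(-c3cccc(NC(=O)Nc4cc(C(F)(F)F)cc(C(F)(F)F)c4)c3)cc2-c2ccncc2)ccc1Cl` likewise gives a limit in this assay, > 50000 nM. Compound 3 `O=C(Nc1cccc(-n2cc(-c3ccncc3)c(-c3ccc(Cl)c(O)c3)n2)c1)Nc1ccc(Cl)c(Cl)c1`, which carries hydrogen in place of methyl on an oxygen on an aromatic ring, also stops at a limit, > 32500 nM. The step that the two limits leave unreadable from compound 2 to compound 3 is therefore of unreadable size. Across the three measured compounds the only evidence is the limit of > 50000 nM in this assay, at which 2 of the 3 values shown sit, and (the limit of > 32500 nM in this assay, at which 1 of the 3 values shown sits), so no step of readable size exists to lean on. Compound 4 `COc1cc(-c2nn(-c3cccc(NC(=O)Nc4ccc(Cl)c(C(F)(F)F)c4)c3)cc2-c2ccncc2)ccc1Cl` differs from compound 2 by trifluoromethyl in place of chloro on an aromatic carbon, the 3,4-dichlorophenyl becoming 4-chloro-3-(trifluoromethyl)phenyl. With every measured value a limit, no direction can be read for this step. Compound 4 is therefore expected to sit again at a limit, with the step that the limit leaves unreadable from compound 2 to compound 4 expected to stay within the scatter. The estimate for compound 4 in this assay is 60000 nM, between 20000 nM and 200000 nM.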

Compound 4, concentration lethal to 50% of the cells: > 32500 nM
Compound 4 was reported as a limit; the forecaster's own chance of this, stated with the estimate: 80%; the middle value does not contradict the limit.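

Within the data shown here, compound 4 also gives only a limit in this assay, > 32500 nM, so compound 2 and compound 4 yield no step of readable size. The compounds shown leave open where any of them would reach a measured value, and whether trifluoromethyl in place of chloro changes it.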